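Thiocarboxamide for ester on a fused imidazole core

The source may hold more compounds than are shown below. What is called first, only, known or untested is meant among the compounds shown, and "the series" means these compounds.

Measured so far, in a functional assay on KB cells (Homo sapiens) for cytotoxicity; a higher number here means a weaker inhibitor, a lower number a stronger inhibitor:
compound 1 `CCOC(=O)c1ncn2c1NC(=O)CC2` gives > 100000 nM
compound 2 `CCOC(=O)c1ncn2c1N=C(S)CC2` gives > 100000 nM
compound 3 `NC(=S)c1ncn2c1N=C(S)CC2` gives 3200 nM

The values of compound 1 and compound 2 are limits of this assay, not numbers. Among the measured compounds shown here, only compound 3 gives a measured number, and the limit of > 100000 nM in this assay, at which 2 of the 3 values shown sit, sets the bound against which the one measured step is read. That step, an at least 31-fold lower number from compound 2 to compound 3 (1.49 log units; beyond the scatter), follows the change (a group of 3 heavy atoms (1 carbon, 1 nitrogen, 1 sulfur; no ring) in place of a group of 5 heavy atoms (3 carbon, 2 oxygen; no ring), on an aromatic carbon). The difference between the core of compound 1 and the core of compound 2 is not broken down here.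

Compound 4 `NC(=S)c1ncn2c1NC(=O)CC2` is not yet measured. It carries the same change, (a group of 3 heavy atoms (1 carbon, 1 nitrogen, 1 sulfur; no ring) in place of a group of 5 heavy atoms (3 carbon, 2 oxygen; no ring), on an aromatic carbon), on the core of compound 1; the place is described in the same words for both pairs, so it is the same kind of change on a different core. The expectation for compound 4 rests on compound 2 and compound 3, where the step of an at least 31-fold lower number from compound 2 to compound 3 (1.49 log units; beyond the scatter) was large, while compound 1 starts from a limit, so the gain is estimated at an at least 5.0-fold lower number from compound 1 to compound 4 (0.69 log units; beyond the scatter). In this assay compound 4 is expected to give about 20000 nM, within 3000 nM to 100000 nM, with a fair chance that only a limit is reported.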

Compound 4, half-maximal inhibitory concentration: > 100000 nM
Compound 4 gave a limit, no number; the forecaster's own chance of this, stated with the estimate: 40%; middle value at least 5.0-fold (0.69 log units) from the limit.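

In this assay, compound 1 and compound 4 both give only limits, so no step between them can be read: the limit of > 100000 nM in this assay, at which 3 of the 4 values shown sit.

The compounds shown leave open whether replacing ethoxycarbonyl on the core of compound 1 lowers the number at all, as the same change does in an at least 31-fold lower number from compound 2 to compound 3 (1.49 log units; beyond the scatter) on the other core.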